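Adding a third methoxy to a dimethoxy curcuminoid analogue

The source may report more compounds than this note shows. Statements on the series, on what has been measured and on what is new or still open speak of the compounds shown alone.

Compound 1 `COc1cc(/C=C2\CCC/C(=C\c3ccc([N+](=O)[O-])cc3)C2=O)ccc1O` and compound 2 `COc1ccc(/C=C2\CCC/C(=C\c3ccc([N+](=O)[O-])cc3)C2=O)cc1OC` share a common core and differ only in one oxygen substituent. In a functional assay on HL-60 cells (Homo sapiens) for cytotoxicity (on this read-out higher numbers stand for lower toxicity in this test and lower numbers for higher toxicity in this test), compound 1 gives 3400 nM, while compound 2 gives 4300 nM. The step of a 1.3-fold higher number from compound 1 to compound 2 (0.10 log units; within the scatter) is small. Among the compounds with values here, compound 2 therefore holds the highest of the two numbers measured so far, but its nearest neighbour, compound 1, sits within the scatter of it, so the two cannot be ordered.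

Compound 3 `COc1cc(/C=C2\CCC/C(=C\c3ccc([N+](=O)[O-])cc3)C2=O)cc(OC)c1OC` has not yet been measured in this assay. It differs from compound 2 by methoxy in place of hydrogen on an aromatic carbon. Within the data shown here, the only step in hand that bears on it is the earlier one from compound 1 to compound 2, which added a methyl to an oxygen and stayed within the scatter. On that basis a step of a 1.0-fold higher number from compound 2 to compound 3 (0.02 log units; within the scatter) is expected, that is, no change beyond the scatter. Compound 3 is accordingly estimated to give 4500 nM in this assay, in a range from 2000 nM to 10000 nM.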

Compound 3, half-maximal cytotoxic concentration: 1100 nM
Compound 3: the middle estimate sits 4.1-fold (0.61 log units) above what was measured, outside the stated range (below it).
By their numbers in this assay, from the lowest: compound 3; then compounds 1 and 2 (each within the scatter of the next).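

In this assay the methoxy entering on the aromatic carbon ortho to a methoxy group gives a 3.9-fold lower number from compound 2 to compound 3 (0.59 log units; beyond the scatter), which points to higher toxicity in this test. The earlier change, a methyl in place of hydrogen on an oxygen, gave only a 1.3-fold higher number from compound 1 to compound 2 (0.10 log units; within the scatter), so this carbon is the first place among the compounds shown where a single change moves the number beyond the scatter. Nothing at hand explains the shift.

The compounds shown leave open whether the step belongs to methoxy as such or would also come with an amine or an ethoxy on this carbon. They also leave open whether the same methoxy would give this step without the methoxy groups already on the ring.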